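This account rests on a few compounds, and the source may have more. Where it says the series, first, only, none or still open, it means among the compounds named here.

Measured so far:
- compound 1, `CCOc1ccc(NC(=O)O/N=C/c2ccc(F)cc2)cc1`: 46 nM
- compound 2, `CCCCCCOc1ccc(NC(=O)O/N=C/c2ccc(F)cc2)cc1`: 6.5 nM

Among the compounds with values here, in an assay on H4 cells for inhibition of Fatty-acid amide hydrolase 1 (Homo sapiens) (on this read-out higher numbers stand for weaker inhibition and lower numbers for stronger inhibition), compound 2 holds the lowest of the two numbers; its nearest neighbour is compound 1, and the only step on record is a 7.1-fold lower number from compound 1 to compound 2 (0.85 log units; beyond the scatter), which leaves compound 2 standing clear beyond the scatter.

Compound 3, `CCCCCCCCCCOc1ccc(NC(=O)O/N=C/c2ccc(F)cc2)cc1`, carries the shared core of compound 2 with one change: butyl in place of hydrogen on a saturated chain carbon, six bonds along the chain from an oxygen on an aromatic ring. The same difference, cut one bond further out, reads methyl to pentyl, ethyl to hexyl, or propyl to heptyl.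

Within the data shown here, one measured step bears on this. It is a 7.1-fold lower number from compound 1 to compound 2 (0.85 log units; beyond the scatter), the same butyl added to the end of the chain, there two bonds along the chain from the oxygen on the aromatic ring. Among the measured compounds shown here, whether a second such lengthening repeats that gain is unknown; only one step along this chain exists, so the account expects a further fall in this assay smaller than that step, or none beyond the scatter.

On that basis compound 3 is estimated at 4 nM in this assay, within 1.5 nM to 15 nM, which would mean an expected step of a 1.6-fold lower number from compound 2 to compound 3 (0.21 log units; within the scatter).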

Compound 3, half-maximal inhibitory concentration: 0.25 nM
For compound 3 the middle estimate is 16-fold (1.20 log units) above the measured one; measured number below the stated range.
By their numbers in this assay, from the lowest: compound 3; then compound 2; then compound 1.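

In this assay the second butyl on this chain did not bring the smaller gain or the flat result that one earlier step left possible: six bonds along the chain from the oxygen on the aromatic ring, the change gives a 26-fold lower number from compound 2 to compound 3 (1.41 log units; beyond the scatter) and so exceeds in printed size the earlier 7.1-fold lower number from compound 1 to compound 2 (0.85 log units; beyond the scatter) at two bonds along the chain. Taken from the shortest chain to the longest, the whole change amounts to a 180-fold lower number from compound 1 to compound 3 (2.26 log units; beyond the scatter) and the number falls at each lengthening, with none of the three compounds going against that order. Compound 3 therefore stands clear of both other compounds, and nothing available explains why the added butyl has this effect at either place on the chain.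

What the compounds leave open is whether a longer chain on the same oxygen would lower the number further, or where the fall would level off or turn back. They also leave open whether chain length alone carries the gain, since a chain of similar reach ending in an amine, a carboxylic acid or a phenyl ring lies outside this set.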